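Ester to Acid on the Aryl Group of Compound 3

The source may report more compounds than this note shows. Statements on the series, on what has been measured and on what is new or still open speak of the compounds shown alone.

Compound 1, `CCCCCN(CCCCC)C(=O)N1CCN(C(=O)N(c2ccccc2)c2cccc(Cl)c2)[C@H](C(=O)O)C1`: 0.4 nM
Compound 2, `CCCCCN(CCCCC)C(=O)N1CCN(C(=O)N(c2ccccc2)c2cccc(Br)c2)[C@H](C(=O)O)C1`: 0.6 nM
Compound 3, `CCCCCN(CCCCC)C(=O)N1CCN(C(=O)N(c2ccccc2)c2ccc(C(=O)OCC)cc2)[C@H](C(=O)O)C1`: 35 nM

All three share one core and differ only in one aryl group on an amide-type nitrogen. In an assay for inhibition of Type-2 angiotensin II receptor (Rattus norvegicus) (a lower number here means a stronger inhibitor, a higher number a weaker inhibitor), compound 3 gives the highest number of the three: an 88-fold higher number from compound 1 to compound 3 (1.94 log units; beyond the scatter) and a 58-fold higher number from compound 2 to compound 3 (1.77 log units; beyond the scatter), whereas a 1.5-fold higher number from compound 1 to compound 2 (0.18 log units; within the scatter). Compound 4, `CCCCCN(CCCCC)C(=O)N1CCN(C(=O)N(c2ccccc2)c2ccc(C(=O)O)cc2)[C@H](C(=O)O)C1`, differs from compound 3 by hydrogen in place of ethyl on an oxygen next to a carbonyl group. Among the compounds with values here, none of the measured steps touches this part of the molecule; each swaps a whole aryl group, so no measured step bears directly on the change, and its direction cannot be read from the data. Compound 4 is therefore expected close to compound 3, with a wide range: 40 nM (10 nM to 200 nM). The expected step is a 1.1-fold higher number from compound 3 to compound 4 (0.06 log units; within the scatter).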

Compound 4, half-maximal inhibitory concentration: 180 nM
Compound 4: the middle estimate sits 4.5-fold (0.65 log units) below what was measured; measured number inside the range.
By their numbers in this assay, from the lowest: compounds 1 and 2 (each within the scatter of the next); then compound 3; then compound 4.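

Replacing ethyl with hydrogen on this oxygen, which turns ethoxycarbonyl into carboxy, changes the result in this assay by itself (a 5.1-fold higher number from compound 3 to compound 4 (0.71 log units; beyond the scatter)). The earlier compounds shown here showed only swaps of a whole aryl group, whereas this step shows that a change confined to the outer end of that group also counts. The gap to the halogen-bearing compounds grows as a result (a 300-fold higher number from compound 2 to compound 4 (2.48 log units; beyond the scatter); a 450-fold higher number from compound 1 to compound 4 (2.65 log units; beyond the scatter)). Nothing available explains the shift. The compounds shown leave open where a methyl or a longer chain on this oxygen would fall, or an amine in place of the ethoxy.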